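The source may report more compounds than this note shows. Statements on the series, on what has been measured and on what is new or still open speak of the compounds shown alone.

Measured so far:
- Compound 1 `Cc1cccc(Cn2c(CN3CCN(C(=O)c4cccs4)CC3)nc3ccccc32)c1`: in an assay on isolated protein for inhibition of aldehyde dehydrogenase 1A1 (Homo sapiens), read by spectrophotometry, tested at 10 uM (a higher number here means more inhibition at the concentration tested (going by the name of the read-out), a lower number less inhibition), compound 1 gives 60.8%
- Compound 2 `Cc1cccc(Cn2c(CN3CCN(C(=O)c4ccc(Cl)cc4)CC3)nc3ccccc32)c1`: compound 2 gives 23.2%
- Compound 3 `CC(=O)N1CCN(Cc2nc3ccccc3n2Cc2cccc(C)c2)CC1`: compound 3 gives 70.3%

Compound 3 holds the highest of the three numbers, though its lead over compound 1 is small: a number 9.5 percentage points higher from compound 1 to compound 3 (within the scatter), a gap within the ordinary scatter of repeated measurements, so the two cannot be ranked. Its lead over compound 2 is clear: a number 47.1 percentage points higher from compound 2 to compound 3 (beyond the scatter).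

Compound 4 `Cc1cccc(Cn2c(CN3CCN(C(=O)C4CCC4)CC3)nc3ccccc32)c1` has not been measured. It differs from compound 3 in one place: cyclobutyl in place of methyl on a carbonyl carbon.

All three known steps swap the group on the carbonyl carbon. Two are large, a number 37.6 percentage points lower from compound 1 to compound 2 (beyond the scatter) and a number 47.1 percentage points higher from compound 2 to compound 3 (beyond the scatter), both involving 4-chlorophenyl; the third, a number 9.5 percentage points higher from compound 1 to compound 3 (within the scatter), is within the scatter. Methyl and thiophen-2-yl sit close together; only 4-chlorophenyl falls far. Cyclobutyl, a small non-aromatic ring, has no direct precedent here, so a modest downward step, or none beyond the scatter, is expected. The expected shift is a number 10.3 percentage points lower from compound 3 to compound 4 (beyond the scatter). Compound 4 is thus estimated at 60%, with a range from 35% to 80%.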

Compound 4, a percentage reported as inhibition, at one concentration (the size of the read-out at that concentration, not a potency): 69.1%
Estimate against measurement, compound 4: 9.1 percentage points below; the measured number falls inside the stated range.
By their numbers in this assay, from the lowest: compound 2; then compounds 1, 4 and 3 (each within the scatter of the next).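

In this assay, four heavy atoms and a non-aromatic ring in place of the single carbon of methyl on the carbonyl carbon leave compound 3 and compound 4 indistinguishable (a number 1.2 percentage points lower from compound 3 to compound 4 (within the scatter)). Cyclobutyl also cannot be separated from thiophen-2-yl (a number 8.3 percentage points higher from compound 1 to compound 4 (within the scatter)), while 4-chlorophenyl stays well apart (a number 45.9 percentage points higher from compound 2 to compound 4 (beyond the scatter)), so among these four compounds, methyl, cyclobutyl and thiophen-2-yl sit level and compound 2 alone stands out, showing that this position accepts a ring of carbon only as well as a single carbon. Nothing available explains why 4-chlorophenyl behaves differently. On these data alone, what remains open is whether plain phenyl, without the chlorine, would fall as far as 4-chlorophenyl. Also open, as far as these compounds go, is how an amine or a longer chain such as hexyl on the same carbonyl carbon would fare.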